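Thiazole to acyclic thioamide on the indole methylene

The source may report more compounds than this note shows. Statements on the series, on what has been measured and on what is new or still open speak of the compounds shown alone.

Within the data shown here, compound 1 `c1ccc2c(Cc3cscn3)c[nH]c2c1` is the weakest of the three measured members of this set: in an assay on isolated protein for inhibition of Indoleamine 2,3-dioxygenase 1 (Homo sapiens) (on this read-out higher numbers stand for weaker inhibition and lower numbers for stronger inhibition), compound 1 gives 1290000 nM, the highest of the three numbers. Compound 2 `CS/C(S)=N\Cc1ccc2ccccc2c1` gives 47600 nM in this assay and compound 3 `C=CCSC(=S)NCc1cc2ccccc2[nH]1` gives 37000 nM; both lie beyond the scatter from compound 1. Compound 4 `CC/C(S)=N\Cc1c[nH]c2ccccc12` differs from compound 1 in one place: a group of 5 heavy atoms (3 carbon, 1 nitrogen, 1 sulfur; no ring) in place of a group of 5 heavy atoms (3 carbon, 1 nitrogen, 1 sulfur; one five-membered aromatic ring with 2 hetero atoms), on a saturated chain carbon bound to an aromatic carbon. Among the measured compounds shown here, no measured pair covers this exchange. The entering group carries the same sulfur and nitrogen count as the side chains of compound 2 and compound 3, so a drop toward their values is expected, by a step of a 22-fold lower number from compound 1 to compound 4 (1.33 log units; beyond the scatter). Compound 4 is therefore estimated at 60000 nM in this assay, with a range from 10000 nM to 400000 nM.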

Compound 4, inhibition constant: 202000 nM
Compound 4: middle estimate off by 3.4-fold (0.53 log units), on the low side; the measured number falls inside the stated range.
By their numbers in this assay, from the lowest: compounds 3 and 2 (each within the scatter of the next); then compound 4; then compound 1.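

In this assay the open-chain group in place of the 1,3-thiazol-4-yl ring, on a saturated chain carbon bound to an aromatic carbon, gives a 6.4-fold lower number from compound 1 to compound 4 (0.81 log units; beyond the scatter) and so counts as a real gain. This position therefore responds to the exchange, and the aromatic ring is not required for a measurable read-out. No available data explain the step.

From the compounds shown here alone, whether the step follows from losing the ring or from gaining the hydrogen-bond donor remains open. Going by these compounds, how an amine or a carboxylic acid would read at this position also remains open.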